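Adding 2-methyl-1,3-thiazol-4-yl to compound 3

A few compounds are considered here, and "the series" means these few. Any claim that something is new, unique, unknown or untested is made for them only; others in the source may bear on it.

In a functional assay on COLO 205 cells (Homo sapiens) for cytotoxicity (a lower number here means a stronger inhibitor, a higher number a weaker inhibitor), compound 3 (`Cc1cc(Nc2nn(C)c(=O)c3ccccc23)n[nH]1`) reads > 30000 nM, which is a limit of the assay and not a number. Compound 1 (`COc1ccc(-n2nc(Nc3cc(C)[nH]n3)c3ccccc3c2=O)cc1`) gives 3700 nM, compound 2 (`Cc1cc(Nc2nn(Cc3cc(F)ccc3F)c(=O)c3ccccc23)n[nH]1`) gives 3800 nM, and the data show a 1.0-fold higher number from compound 1 to compound 2 (0.01 log units; within the scatter). Compound 4 (`Cc1cc(Nc2nn(Cc3csc(C)n3)c(=O)c3ccccc23)n[nH]1`) differs from compound 3 as follows: 2-methyl-1,3-thiazol-4-yl in place of hydrogen on a saturated chain carbon bound to an aromatic nitrogen. For the measured compounds named here, two measured steps bear on this change, namely an at least 8.1-fold higher number from compound 1 to compound 3 (0.90 log units; beyond the scatter) and an at least 7.8-fold higher number from compound 2 to compound 3 (0.89 log units; beyond the scatter). Compound 2 is the closer case, since its group also stands on a saturated chain carbon bound to an aromatic nitrogen. A step of similar size toward a lower number is therefore expected, read here as an expected at least 5.0-fold lower number from compound 3 to compound 4 (0.69 log units; beyond the scatter). For compound 4 the estimate is 6000 nM, with an expected range from 2000 nM to 20000 nM.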

Compound 4, half-maximal inhibitory concentration: > 30000 nM
Compound 4: only a limit was reported (the forecaster's own chance of this, stated with the estimate: 20%); middle value at least 5.0-fold (0.69 log units) from the limit.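

In this assay compound 4 reads > 30000 nM, which is a limit of the assay and not a number. Placing 2-methyl-1,3-thiazol-4-yl on the saturated chain carbon bound to an aromatic nitrogen in place of 2,5-difluorophenyl gives an at least 7.8-fold higher number from compound 2 to compound 4 (0.89 log units; beyond the scatter), and (2-methyl-1,3-thiazol-4-yl)methyl in place of 4-methoxyphenyl on the aromatic nitrogen gives an at least 8.1-fold higher number from compound 1 to compound 4 (0.90 log units; beyond the scatter), so not every group at this position reads like compound 2. The step from compound 3 to compound 4 cannot be read: the limit of > 30000 nM in this assay, at which 2 of the 4 values shown sit.

As far as these compounds go, how compound 3 and compound 4 truly compare stays open. Also open, from the compounds shown here alone, is whether a pyridinyl or an unsubstituted phenyl on this carbon would read like compound 2 or like compound 4.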